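Compound 3 to compound 4: a new aromatic group

The source may hold more compounds than are shown below. What is called first, only, known or untested is meant among the compounds shown, and "the series" means these compounds.

Compound 1 `O=C(Cc1csc2nc(-c3ccc(Br)cc3)cn12)N/N=C/c1ccccc1`: 13500 nM
Compound 2 `O=C(Cc1csc2nc(-c3ccc(Br)cc3)cn12)N/N=C/c1ccc(O)cc1`: 21400 nM
Compound 3 `COc1cccc(OC)c1/C=N/NC(=O)Cc1csc2nc(-c3ccc(Br)cc3)cn12`: 12900 nM

All three values come from a functional assay on NCI/ADR-RES cells (Homo sapiens) for inhibition, read by sulforhodamine B assay, with a stated time of 48 h; on this read-out lower numbers stand for stronger inhibition of growth and higher numbers for weaker inhibition of growth. Compound 3 stands level with the other two, since no gap among them lies beyond the scatter. Compound 4 `O=C(Cc1csc2nc(-c3ccc(Br)cc3)cn12)N/N=C/c1ccc(Cl)cc1Cl` brings one change: 2,4-dichlorophenyl in place of 2,6-dimethoxyphenyl on a carbon with a double bond to nitrogen. In words, this is 2,4-dichlorophenyl in place of 2,6-dimethoxyphenyl on a carbon with a double bond to nitrogen. Three measured steps altered this same aromatic group: a 1.6-fold higher number from compound 1 to compound 2 (0.20 log units; within the scatter), a 1.0-fold lower number from compound 1 to compound 3 (0.02 log units; within the scatter) and a 1.7-fold lower number from compound 2 to compound 3 (0.22 log units; within the scatter). For the measured compounds named here, all stayed within the scatter, although no measured compound carries chlorine. In this assay, no step beyond the scatter is therefore expected, and the expected step is a 1.0-fold higher number from compound 3 to compound 4 (0.00 log units; within the scatter). Compound 4 is estimated at 13000 nM, with an expected range of 6500 nM to 26000 nM.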

Compound 4, concentration for 50% growth inhibition: 17400 nM
Estimate against measurement, compound 4: 1.3-fold (0.13 log units) below; low and high end bracket the measured number.
By their numbers in this assay, from the lowest: compounds 3, 1, 4 and 2 (each within the scatter of the next).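

In this assay the 2,4-dichlorophenyl group, the only one here that carries chlorine, stays within the scatter of all three earlier groups (a 1.3-fold higher number from compound 3 to compound 4 (0.13 log units; within the scatter)), (a 1.2-fold lower number from compound 2 to compound 4 (0.09 log units; within the scatter)) and (a 1.3-fold higher number from compound 1 to compound 4 (0.11 log units; within the scatter)). The aromatic group on this carbon has now been changed in several ways, and no change has moved the number beyond the scatter. No evidence is available that would explain this flat result.

Still open, from the compounds shown here alone, is whether this position responds to anything else. An amine or a carboxylic acid on the ring, or cyclohexyl in place of the aromatic ring, could test that.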